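A few compounds are considered here, and "the series" means these few. Any claim that something is new, unique, unknown or untested is made for them only; others in the source may bear on it.

Compound 1, `Cc1ccc(Cn2cc(CNC(=O)c3cnc(Nc4ccc(C#N)cc4)cc3Oc3c(C)cc(C)cc3C)nn2)cc1`, gives in an ADME assay on MT4 cells (Homo sapiens) for cytotoxicity, read by MTT assay, with a stated time of 5 days (on this read-out higher numbers stand for lower toxicity in this test and lower numbers for higher toxicity in this test), a value of 165000 nM. Compound 2, `Cc1cc(C)c(Oc2cc(Nc3ccc(C#N)cc3)ncc2C(=O)NCc2cn(Cc3ccccc3C#N)nn2)c(C)c1`, gives in this assay only a limit of the test, > 219000 nM. Compound 3, `Cc1cc(C)c(Oc2cc(Nc3ccc(C#N)cc3)ncc2C(=O)NCc2cn(Cc3ccccc3Cl)nn2)c(C)c1`, also gives in this assay only a limit, >= 188000 nM.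

Compound 3 thus stands at a limit rather than at a number, and among the three values shown one further value is also a limit; the two limits are the limit of > 219000 nM in this assay, at which 1 of the 3 values shown sits, and (the limit of >= 188000 nM in this assay, at which 1 of the 3 values shown sits). Compound 4, `Cc1cc(C)c(Oc2cc(Nc3ccc(C#N)cc3)ncc2C(=O)NCc2cn(CC(N)=O)nn2)c(C)c1`, differs from compound 3 in one place: carbamoyl in place of 2-chlorophenyl on a saturated chain carbon bound to an aromatic nitrogen. For the measured compounds named here, two measured steps touch the same position. The step of an at least 1.1-fold higher number from compound 1 to compound 3 (0.05 log units; that floor lies within the scatter), and the step that the two limits leave unreadable from compound 2 to compound 3. Going by the values given here, neither exchange at this position moved the read-out beyond the scatter, and for the carbamoyl that enters in compound 4 no measured step exists. Compound 4 is therefore expected to sit close to the limit again. The expected step is a step that the limit leaves unreadable from compound 3 to compound 4, within the scatter. The estimate for compound 4 in this assay is 190000 nM, with a range from 100000 nM to 320000 nM, and a limit rather than a number remains the likeliest outcome.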

Compound 4, half-maximal cytotoxic concentration: 24000 nM
Compound 4: the middle estimate sits 7.9-fold (0.90 log units) above what was measured; the whole stated range lies above it.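

In this assay this position proves not to be indifferent to what it carries: the exchanges among 4-methylphenyl, 2-cyanophenyl and 2-chlorophenyl gave only steps that stayed within the scatter or could not be read, whereas carbamoyl brings a real fall in the number, and so higher toxicity in this test (a 6.9-fold lower number from compound 1 to compound 4 (0.84 log units; beyond the scatter)). The steps from the other two compounds point the same way (an at least 7.8-fold lower number from compound 3 to compound 4 (0.89 log units; beyond the scatter); an at least 9.1-fold lower number from compound 2 to compound 4 (0.96 log units; beyond the scatter)), and both are floors, since compound 2 and compound 3 each stand at a limit of the test rather than at a number. For the compounds shown here, compound 4 is also the only one of the four compounds with no ring at this place, so the lower number goes with the absence of the ring, and none of the four goes against this, though the pattern rests on compound 4 alone.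

As far as these compounds go, whether a carboxylic acid, an amine or a longer chain ending in the carbamoyl would sit with compound 4 or with the three ring-bearing compounds stays open. Whether the loss of the ring or the entry of the carbamoyl counts here cannot be separated, and nothing shown gives a cause for the fall.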